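The source may hold more compounds than are shown below. What is called first, only, known or untested is meant among the compounds shown, and "the series" means these compounds.

Among the compounds with values here, compound 1 `CN1C(=O)C=C(Cl)C1(O)c1ccccc1` holds the highest of the three numbers known in an assay on cell membranes for displacement of a labelled ligand from Cholecystokinin receptor type A (Rattus norvegicus), read by CCK-8 assay, with a stated time of 2 h; on this read-out higher numbers stand for weaker inhibition and lower numbers for stronger inhibition: in this assay compound 1 gives 2500 nM. Compound 2 `CN1C(=O)C=C(Cl)C1(O)c1ccc(Cl)cc1`, which carries chloro in place of hydrogen on an aromatic carbon, gives 2000 nM, and the step of a 1.3-fold lower number from compound 1 to compound 2 (0.10 log units; within the scatter) stays within the scatter. Compound 3 `CC(C)N1C(=O)C=C(Cl)C1(O)c1ccc(Cl)cc1` gives 300 nM; the step of a 6.7-fold lower number from compound 2 to compound 3 (0.82 log units; beyond the scatter) lies beyond the scatter, so isopropyl in place of methyl on the ring nitrogen clearly lowers the number. Compound 4 `CC(C)CN1C(=O)C=C(Cl)C1(O)c1ccccc1` differs from compound 1 by isopropyl in place of hydrogen on a saturated chain carbon bound to an amide-type nitrogen in a ring. Within the data shown here, no measured pair shows exactly this change, but the step from compound 2 to compound 3 enlarges the substituent on the same nitrogen in a related way, while the unsubstituted phenyl ring of compound 1 is kept. Among the measured compounds shown here, compound 4 is therefore expected to give a lower number than compound 1, the step of a 5.0-fold lower number from compound 1 to compound 4 (0.70 log units; beyond the scatter), with a wide margin since only one measured step supports this. The estimate for compound 4 is 500 nM, within a range from 150 nM to 1500 nM.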

Compound 4, half-maximal inhibitory concentration: 20 nM
Compound 4: the middle estimate sits 25-fold (1.40 log units) above what was measured; the measured number lies below the stated range.
By their numbers in this assay, from the lowest: compound 4; then compound 3; then compounds 2 and 1 (each within the scatter of the next).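

In this assay, within the data shown here, the substituent on the ring nitrogen turns out to matter far more than the earlier compounds showed: going from methyl to isobutyl gives a 130-fold lower number from compound 1 to compound 4 (2.10 log units; beyond the scatter), a large step. The earlier change on this nitrogen, from methyl to isopropyl on the chlorinated compounds, gave only a modest step, a 6.7-fold lower number from compound 2 to compound 3 (0.82 log units; beyond the scatter), and the chloro change on the aromatic carbon stayed within the scatter, a 1.3-fold lower number from compound 1 to compound 2 (0.10 log units; within the scatter). Nothing available here explains why adding isopropyl to this saturated chain carbon has so large an effect.

The compounds shown leave open whether a longer chain, a cyclohexyl ring or a terminal amine at this position would lower the number further or raise it. They also leave open whether chloro on the aromatic carbon would change the number for the isobutyl compound.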